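From Methyl to Ethyl: A Cytotoxicity Limit Under Test

A few compounds are considered here, and "the series" means these few. Any claim that something is new, unique, unknown or untested is made for them only; others in the source may bear on it.

In an ADME assay on MT4 cells (Homo sapiens) for cytotoxicity, read by MTT assay (a lower number here means that less compound is tolerated, a higher number that more compound is tolerated), compound 2 `Cc1c(Cc2c(Cl)cccc2Cl)nc(SCC(=O)c2ccc(F)cc2)[nH]c1=O` gives > 57000 nM, which is a limit and not a number. Compound 1 `COc1ccc(CCSc2nc(Cc3c(Cl)cccc3Cl)c(C)c(=O)[nH]2)cc1` gives > 57000 nM, again a limit. Compound 3 `COc1ccc(C(=O)CSc2nc(Cc3c(Cl)cccc3Cl)c(C)c(=O)[nH]2)cc1` gives > 56000 nM, also a limit. None of the three therefore has an exact reading.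

Compound 4 `CCc1c(Cc2c(Cl)cccc2Cl)nc(SCC(=O)c2ccc(F)cc2)[nH]c1=O` differs from compound 2 by one change, (methyl in place of hydrogen on a saturated chain carbon bound to an aromatic carbon). The same difference, cut one bond further out, reads methyl to ethyl.

Among the measured compounds shown here, two measured steps bear on this only indirectly, since neither changes that place: a step that the two limits leave unreadable from compound 1 to compound 2, and a step that the two limits leave unreadable from compound 2 to compound 3. Neither has a readable size, so they offer no measure for the new change. For the measured compounds named here, they show only that both changes left the reading at a limit.

No shift beyond the usual scatter is expected in this assay, and the expected change is an at least 1.0-fold lower number from compound 2 to compound 4 (0.01 log units; that floor lies within the scatter). A limit is also the likely outcome for compound 4. For compound 4, the estimated value is 55000 nM, with an expected range from 25000 nM to 80000 nM.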

Compound 4, half-maximal cytotoxic concentration: > 55000 nM
Compound 4: no number, only a limit; the forecaster's own chance of this, stated with the estimate: 80%; the middle value sits exactly at the limit.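

In this assay compound 4 gives > 55000 nM, a limit and not a number. Compound 2 also stands at a limit, and the step between compound 2 and compound 4 cannot be read. The compounds shown leave open whether adding this methyl changes the concentration tolerated at all.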